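The compounds below may be only part of what the source reports. "The series", "measured", "known", "first", "only" and "open" are said of these compounds alone.

Compound 3 `CC(C)c1cccc(C(C)C)c1NC(=O)NCC1(c2ccc(N)cc2)CCCC1` gives 29 nM in an assay on microsomes for inhibition of acyl-CoA:cholesterol acyltransferase (Oryctolagus cuniculus); on this read-out higher numbers stand for weaker inhibition and lower numbers for stronger inhibition. Compound 1 `COc1ccc(C2(CNC(=O)Nc3c(C(C)C)cccc3C(C)C)CCCC2)cc1` gives 31 nM and compound 2 `CC(C)c1cccc(C(C)C)c1NC(=O)NCC1(c2cccc(OCc3ccccc3)c2)CCCC1` gives 30 nM in this assay, so the three numbers sit level with one another, every gap among them within the scatter, and compound 3 cannot be set apart from either neighbour. Among the measured compounds shown here, the one single-point step among the three, a 1.1-fold lower number from compound 1 to compound 3 (0.03 log units; within the scatter), swaps the group on the aromatic ring that hangs from the saturated ring and leaves the number where it was.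

Compound 4 `CC(C)c1cccc(C(C)C)c1NC(=O)NCC1(c2cccc(CO)c2)CCCC1` differs from compound 3 by 3-(hydroxymethyl)phenyl in place of 4-aminophenyl on a saturated ring carbon. This change touches the same part of the molecule as the step from compound 1 to compound 3, which stayed within the scatter, and compound 2, whose aromatic ring carries its substituent in a further arrangement, shows a value that does not depart from compound 3 either. On these numbers the exchange of the aromatic substituent has so far produced nothing beyond the scatter, and for compound 4 a step of a 1.0-fold higher number from compound 3 to compound 4 (0.01 log units; within the scatter) is therefore expected, without a direction worth naming. The estimate for compound 4 in this assay is 30 nM, with a range from 12 nM to 75 nM.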

Compound 4, half-maximal inhibitory concentration: 15 nM
Estimate against measurement, compound 4: 2.0-fold (0.30 log units) above; the range from low to high includes it.
By their numbers in this assay, from the lowest: compounds 4, 3, 2 and 1 (each within the scatter of the next, the first and the last beyond it).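

In this assay, among the compounds shown here, the step of a 2.1-fold lower number from compound 1 to compound 4 (0.32 log units; beyond the scatter) is the first to pass the scatter, if only modestly, so the aryl group on the saturated ring carbon can shift the number after all. The other two steps stay within the scatter, a 1.9-fold lower number from compound 3 to compound 4 (0.29 log units; within the scatter) and a 2.0-fold lower number from compound 2 to compound 4 (0.30 log units; within the scatter), which means that compound 4 separates from compound 1 alone and cannot be set apart from compound 3 or compound 2. Nothing available explains the gap between compound 1 and compound 4.

The exchange of 4-methoxyphenyl for 3-(hydroxymethyl)phenyl alters both the group and its place on the aromatic ring, and the compounds shown do not separate these two changes, so it stays unclear which of them accounts for the step. As far as these compounds go, it also remains open whether a carboxylic acid or a longer chain ending in hydroxyl, in place of the hydroxymethyl, would widen the gap to compound 1 or bring the number back level with the others.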